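Swapping a dimethylthiazolyl for methyl on a hydroxyphenyl

This account rests on a few compounds, and the source may have more. Where it says the series, first, only, none or still open, it means among the compounds named here.

Compound 1, `Cc1nc(-c2cccc(CNc3ccc4[nH]nc(C(=O)O)c4c3)c2O)sc1C`: 25 nM
Compound 2, `CN(C)c1noc(-c2cccc(CNc3ccc4[nH]ncc4c3)c2O)n1`: 12000 nM

In an assay on isolated protein for inhibition of 2-Hydroxyacid oxidase 1 (Homo sapiens), with stated times of 30 min and 15 min (a higher number here means a weaker inhibitor, a lower number a stronger inhibitor), compound 1 gives 25 nM, the lowest of the two numbers shown. Compound 2 gives 12000 nM, and the gap between the two lies beyond the scatter.

The next compound is compound 3, `Cc1cccc(CNc2ccc3[nH]nc(C(=O)O)c3c2)c1O`. It differs from compound 1 in one place: methyl in place of 4,5-dimethyl-1,3-thiazol-2-yl on an aromatic carbon. Within the data shown here, no measured pair shows this kind of change, so its effect is uncertain. The expectation is a step toward a weaker inhibitor, beyond the scatter, of about a 12-fold higher number from compound 1 to compound 3 (1.08 log units; beyond the scatter). Compound 3 is therefore estimated at 300 nM, with a range from 60 nM to 1500 nM.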

Compound 3, half-maximal inhibitory concentration: 17000 nM
The estimate for compound 3 lay 57-fold (1.75 log units) below the measured number; the measured number lies above the stated range.
By their numbers in this assay, from the lowest: compound 1; then compounds 2 and 3 (each within the scatter of the next).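

In this assay, putting methyl in place of 4,5-dimethyl-1,3-thiazol-2-yl on the aromatic carbon ortho to a hydroxy group gives a 680-fold higher number from compound 1 to compound 3 (2.83 log units; beyond the scatter) with the rest of the molecule unchanged. This large step shows that strong inhibition in this series depends heavily on what sits at this position, and that methyl cannot replace the ring there. No measurement shown explains the size of this loss. On these data alone, whether a phenyl ring or an unsubstituted 1,3-thiazol-2-yl at this position would restore the strength of compound 1 remains open.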